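A few compounds are considered here, and "the series" means these few. Any claim that something is new, unique, unknown or untested is made for them only; others in the source may bear on it.

Values so far in a physicochemical assay for solubility, read by HPLC, using the shake flask method (on this read-out lower numbers stand for lower solubility and higher numbers for higher solubility), for three compounds that share one core:
- compound 1 `COC(=O)c1cccc(-c2cnc3[nH]cc(-c4ccccc4)c3c2)c1` gives 2500 nM
- compound 2 `COC(=O)c1cccc(-c2cnc3[nH]cc(-c4cncnc4)c3c2)c1` gives 4600 nM
- compound 3 `COC(=O)c1cccc(-c2cnc3[nH]cc(-c4cccnc4)c3c2)c1` gives 1900 nM

Compound 3 stands at 1900 nM on these numbers. Its position is split: the series shows a 1.3-fold lower number from compound 1 to compound 3 (0.12 log units; within the scatter) and also a 2.4-fold lower number from compound 2 to compound 3 (0.38 log units; beyond the scatter) in the same read-out.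

Next is compound 4 `N#Cc1cccc(-c2cnc3[nH]cc(-c4cccnc4)c3c2)c1` with cyano in place of methoxycarbonyl on an aromatic carbon of a six-membered aromatic ring of carbon only, meta to a large group (cyano in place of methoxycarbonyl on an aromatic carbon). Among the compounds with values here, none of the measured steps touches this group. All three exchange the other aromatic group, so they give only a rough idea of how far numbers move in this series. Alongside the two steps above, the third is a 1.8-fold higher number from compound 1 to compound 2 (0.26 log units; within the scatter) in the same read-out.

Within the data shown here, with no measured precedent for this change, no step beyond the scatter is expected in this assay and the direction remains open, with a slight lean upward. The estimated step is a 1.3-fold higher number from compound 3 to compound 4 (0.12 log units; within the scatter) and this remains a weakly supported expectation. The estimate for compound 4 is 2500 nM with an expected range from 800 nM to 7000 nM in this read-out.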

Compound 4, solubility: 7200 nM
Estimate against measurement, compound 4: 2.9-fold (0.46 log units) below; the measured number lies above the stated range.
By their numbers in this assay, from the lowest: compounds 3, 1, 2 and 4 (each within the scatter of the next, the first and the last beyond it).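

In this assay, the first change shown on the six-membered aromatic ring of carbon only, cyano in place of methoxycarbonyl, gives a 3.8-fold higher number from compound 3 to compound 4 (0.58 log units; beyond the scatter). This puts a step beyond the scatter at a place that the earlier exchanges of the other aromatic group left untouched, so the number in this series responds to the group meta to a large group as well as to that aromatic group. The change alters several counted features at once, with four heavy atoms giving way to two, two hydrogen-bond acceptors to one, and a double bond to a triple bond, and nothing shown links the step to any one of these or otherwise explains it.

Within the data shown here, whether the step carries over when phenyl or pyrimidin-5-yl stands in place of pyridin-3-yl remains open, since the pair of compound 3 and compound 4 is the only reading of this change. Also open, on these data alone, is how a carboxylic acid, a primary amide or an aminomethyl group would read at the same aromatic carbon, and with that whether the step belongs to cyano itself or to the loss of methoxycarbonyl.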